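From phenyl to furan-2-yl in a small series

The source may hold more compounds than are shown below. What is called first, only, known or untested is meant among the compounds shown, and "the series" means these compounds.

Measured in a functional assay on the whole organism with Mus musculus as the target; a lower number here means that less compound is needed, a higher number that more compound is needed for the effect:
compound 1 `CN(C)C(=O)Cn1c(-c2ccccc2)nc2cccnc21`: 35 mg/kg
compound 2 `CN(C)C(=O)Cn1c(-c2ccc([N+](=O)[O-])cc2)nc2cccnc21`: 47 mg/kg
compound 3 `CN(C)C(=O)Cn1c(-c2ccc(C(F)(F)F)cc2)nc2cccnc21`: 3.2 mg/kg

Compound 1 stands level with one neighbour and well above the other. Nitro in place of hydrogen gives a 1.3-fold higher number from compound 1 to compound 2 (0.13 log units; within the scatter), whereas trifluoromethyl in place of hydrogen gives an 11-fold lower number from compound 1 to compound 3 (1.04 log units; beyond the scatter).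

Compound 4 `CN(C)C(=O)Cn1c(-c2ccco2)nc2cccnc21` carries furan-2-yl in place of phenyl (furan-2-yl in place of phenyl on an aromatic carbon). The measured steps only alter a group on the phenyl and never replace the phenyl itself, so they bear on this change only loosely. They do show that a single change can matter a great deal, or hardly at all. No direction follows from them, so no step beyond the scatter is expected in this assay. The estimated step is a 1.1-fold higher number from compound 1 to compound 4 (0.06 log units; within the scatter). For compound 4 the expected value is 40 mg/kg, with an estimated range of 12 mg/kg to 120 mg/kg.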

Compound 4, dose for half-maximal effect: > 100 mg/kg
Compound 4 was reported as a limit; the forecaster's own chance of this, stated with the estimate: 10%; at least 2.5-fold (0.39 log units) between middle value and limit.
By their numbers in this assay, from the lowest: compound 3; then compounds 1 and 2 (each within the scatter of the next). At a limit, above all of these: compound 4.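

In this assay, replacing the phenyl itself with furan-2-yl gives an at least 2.8-fold higher number from compound 1 to compound 4 (0.45 log units; beyond the scatter), so the ring at this position matters, and not only the groups placed on it. Compound 4 is reported only as a limit, so the full size of this step remains unknown: the limit of > 100 mg/kg in this assay, at which 1 of the 4 values shown sits.

Going by these compounds, it remains open whether a trifluoromethyl group on furan-2-yl would lower the number as it does on the phenyl. On these data alone, it is also open whether a thiophene or pyridine ring at this position would behave more like phenyl or like furan-2-yl.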